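The source may report more compounds than this note shows. Statements on the series, on what has been measured and on what is new or still open speak of the compounds shown alone.

In a functional assay on Bel-7402 cells (Homo sapiens) for antiproliferative activity, read by MTT assay, with a stated time of 72 h (on this read-out lower numbers stand for stronger inhibition and higher numbers for weaker inhibition), compound 2 `COc1cccc(NC(=O)C(Cl)Cl)c1` gives 54800 nM. Within the data shown here, of the two numbers measured so far, this is the one compound 2 sets, with compound 1 `N#Cc1cccc(NC(=O)C(Cl)Cl)c1` alongside at 48400 nM in this assay, the two lying within the scatter of each other. Compound 3 `O=C(Nc1cccc(C(F)(F)F)c1)C(Cl)Cl` differs from compound 2 by trifluoromethyl in place of methoxy on an aromatic carbon. Among the measured compounds shown here, the only measured step that bears on this change, a swap of one substituent at the same aromatic carbon, was a 1.1-fold higher number from compound 1 to compound 2 (0.05 log units; within the scatter). One therefore expects no step beyond the scatter for compound 3 in this assay, a 1.1-fold lower number from compound 2 to compound 3 (0.04 log units; within the scatter). Compound 3 is estimated at 50000 nM, with a range from 20000 nM to 125000 nM.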

Compound 3, half-maximal inhibitory concentration: 5970 nM
Beside the measured number, compound 3's estimate is 8.4-fold (0.92 log units) above it; measured number outside the range, below it.
By their numbers in this assay, from the lowest: compound 3; then compounds 1 and 2 (each within the scatter of the next).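

In this assay this aromatic carbon proves sensitive to the group it carries, which the earlier swap of cyano for methoxy, a step within the scatter, did not reveal. Trifluoromethyl stands apart from both earlier groups, with a 9.2-fold lower number from compound 2 to compound 3 (0.96 log units; beyond the scatter) and an 8.1-fold lower number from compound 1 to compound 3 (0.91 log units; beyond the scatter), both beyond the scatter. No evidence at hand accounts for this difference. The compounds shown leave open whether the stronger inhibition is particular to trifluoromethyl or would also appear with a chlorine atom or a methyl group on this carbon. They also leave open how an amine or a carboxylic acid there would fare.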